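Dithiocarbamate series: variation of the piperazine substituent

This account rests on a few compounds, and the source may have more. Where it says the series, first, only, none or still open, it means among the compounds named here.

Measured compounds:
- Compound 1, `Nc1nc(N)c2cc(CSC(=S)N3CCN(C4CCCCC4)CC3)ccc2n1`, 4050 nM
- Compound 2, `Cc1ccc(N2CCN(C(=S)SCc3ccc4nc(N)nc(N)c4c3)CC2)c(C)c1`, 2970 nM
- Compound 3, `Nc1nc(N)c2cc(CSC(=S)N3CCN(c4ccccc4Cl)CC3)ccc2n1`, 3900 nM

The three values above come from a functional assay on HT-29 cells (Homo sapiens) for antiproliferative activity, read by MTT assay, with a stated time of 72 h; on this read-out higher numbers stand for weaker inhibition and lower numbers for stronger inhibition. Compound 3 stands second highest of the three numbers; its nearest neighbour is compound 1 (a 1.0-fold lower number from compound 1 to compound 3 (0.02 log units; within the scatter)), and the other gap is a 1.3-fold higher number from compound 2 to compound 3 (0.12 log units; within the scatter), so the three compounds cannot be ordered. The remaining step, a 1.4-fold lower number from compound 1 to compound 2 (0.13 log units; within the scatter), is also within the scatter.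

Compound 4, `Nc1nc(N)c2cc(CSC(=S)N3CCN(c4ccccc4[N+](=O)[O-])CC3)ccc2n1`, differs from compound 3 by nitro in place of chloro on an aromatic carbon. Within the data shown here, no measured step touches this position. Among the measured compounds shown here, the only step that alters the phenyl ring substituents, a 1.3-fold higher number from compound 2 to compound 3 (0.12 log units; within the scatter), lies within the scatter, and the step from cyclohexyl to either aryl group was likewise small. Nothing here points in either direction, so in this assay no step beyond the scatter is expected.

Compound 4 is therefore estimated at 3800 nM, range 1500 nM to 9500 nM, an expected step of a 1.0-fold lower number from compound 3 to compound 4 (0.01 log units; within the scatter).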

Compound 4, half-maximal inhibitory concentration: 4310 nM
Compound 4: middle estimate off by 1.1-fold (0.05 log units), on the low side; low and high end bracket the measured number.
By their numbers in this assay, from the lowest: compounds 2, 3, 1 and 4 (each within the scatter of the next).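

In this assay, swapping one group for another on this aromatic carbon gives a 1.1-fold higher number from compound 3 to compound 4 (0.04 log units; within the scatter), so chloro and nitro are not told apart here, even though nitro brings more heavy atoms and hydrogen-bond acceptors. The comparisons with the other piperazine substituents, a 1.5-fold higher number from compound 2 to compound 4 (0.16 log units; within the scatter) and a 1.1-fold higher number from compound 1 to compound 4 (0.03 log units; within the scatter), also stay within the scatter, so the 2-nitrophenyl group joins cyclohexyl, 2,4-dimethylphenyl and 2-chlorophenyl in a set that cannot be ordered. No measured evidence bears on this result.

Going by these compounds, whether a different group on this carbon, such as an amine or a carboxylic acid, would give a step beyond the scatter remains open. Also open, on these data alone, is whether nitro or chloro would behave the same way on another carbon of the phenyl ring.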